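The source may hold more compounds than are shown below. What is called first, only, known or untested is meant among the compounds shown, and "the series" means these compounds.

Measured so far:
compound 1 `C=C1C(=O)[C@]23C[C@H]1CC[C@H]2[C@@]1(CCC[C@@]2(C)CO[C@@H](OC)[C@H]21)COC3=O` – 0.18 ug/mL
compound 2 `C=C1C(=O)[C@]23C[C@H]1C[C@@H](O)[C@H]2[C@@]1(CCC[C@@]2(C)CO[C@H](OC)[C@H]21)COC3=O` – 0.23 ug/mL

In a functional assay on K562 cells (Homo sapiens) for cytotoxicity, read by MTT assay (a higher number here means a weaker inhibitor, a lower number a stronger inhibitor), compound 1 gives 0.18 ug/mL. In this assay compound 2 gives 0.23 ug/mL; of the two numbers it is the higher, but its nearest neighbour is compound 1 and the gap between them is within the scatter, so the two compounds are not distinguished by these data.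

Compound 3 `C=C1C(=O)[C@]23C[C@H]1C[C@@H](O)[C@H]2[C@@]1(CCC[C@@]2(C)CO[C@@H](OC)[C@H]21)COC3=O` has not been measured. It differs from compound 2 as follows: the two compounds have the same atoms and bonds and differ only in configuration as drawn: 1 of 8 stereo elements differ; a stereocentre at a saturated ring carbon is drawn S in compound 2 and R in compound 3. Nothing leaves and nothing enters; only the drawn configuration at that one stereocentre changes.

Within the data shown here, no step between measured compounds exists to calibrate such a change. The two measured numbers sit close together, so no step beyond the scatter is expected in this assay in either direction. For compound 3 the expected value is 0.22 ug/mL (range 0.1 ug/mL to 0.45 ug/mL), which would mean a step of a 1.0-fold lower number from compound 2 to compound 3 (0.02 log units; within the scatter).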

Compound 3, half-maximal inhibitory concentration: 0.87 ug/mL
Compound 3: middle estimate off by 4.0-fold (0.60 log units), on the low side; the measured number lies above the stated range.
By their numbers in this assay, from the lowest: compounds 1 and 2 (each within the scatter of the next); then compound 3.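

In this assay the drawn configuration at this one saturated ring carbon matters, with a 3.8-fold higher number from compound 2 to compound 3 (0.58 log units; beyond the scatter). Among these compounds, the earlier numbers offered no step between compounds differing in one place, whereas this step can be tied to a single change: the fact that compounds 2 and 3 differ only in the configuration as drawn. Hydroxy in place of hydrogen on a saturated ring carbon also gives a step beyond the scatter, a 4.8-fold higher number from compound 1 to compound 3 (0.68 log units; beyond the scatter), so neither single change is silent in this series.

Whether the same change from S to R would give a similar step in a compound without the hydroxy remains open, since only one such pair is shown. Also open, going by these compounds, is how an amine or a carboxylic acid in place of the hydroxy would read in this assay.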